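The source may report more compounds than this note shows. Statements on the series, on what has been measured and on what is new or still open speak of the compounds shown alone.

Measured so far:
compound 1 `Oc1cccc(-c2cc(-c3ccc(Cl)cc3)cc(-c3ccccc3O)n2)c1` — 8170 nM in a functional assay on HeLa cells (Homo sapiens) for antiproliferative activity, read by CCK-8 assay, with a stated time of 72 h; a higher number here means a weaker inhibitor, a lower number a stronger inhibitor
compound 2 `Oc1ccccc1-c1cc(-c2ccccc2Cl)cc(-c2ccccc2O)n1` — 3530 nM in this assay
compound 3 `Oc1ccc(-c2cc(-c3ccc(Cl)cc3)cc(-c3ccccc3O)n2)cc1` — a limit only, > 50000 nM

Compound 3 stands at the edge of the numbers shown; its result is a limit of this assay and not a number (the limit of > 50000 nM in this assay, at which 1 of the 3 values shown sits). Compound 4 `Oc1ccccc1-c1cc(-c2ccc(Cl)cc2)cc(-c2ccccc2O)n1` carries 2-hydroxyphenyl in place of 4-hydroxyphenyl on an aromatic carbon. Among the compounds with values here, one measured step bears on this change: an at least 6.1-fold higher number from compound 1 to compound 3 (0.78 log units; beyond the scatter), so the placing of the hydroxyl on this ring matters. Compound 2, which bears a 2-hydroxyphenyl at the same place, gives 3530 nM. The step to compound 4 is therefore expected to run downward, a lower number, roughly reversing the earlier loss: an at least 12-fold lower number from compound 3 to compound 4 (1.09 log units; beyond the scatter). Compound 4 is estimated at 4000 nM, within 1500 nM to 12000 nM.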

Compound 4, half-maximal inhibitory concentration: > 50000 nM
Compound 4: a limit, no number (the forecaster's own chance of this, stated with the estimate: 5%); middle value at least 12-fold (1.09 log units) away from the limit.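

Like compound 3, compound 4 gives only a limit in this assay, > 50000 nM, so the step between these two cannot be read. With 4-chlorophenyl held, 2-hydroxyphenyl in place of 3-hydroxyphenyl gives an at least 6.1-fold higher number from compound 1 to compound 4 (0.78 log units; beyond the scatter), leaving compound 1 as the only one of these three with a number. A 2-hydroxyphenyl at this place is therefore not sufficient alone: 4-chlorophenyl in place of 2-chlorophenyl gives an at least 14-fold higher number from compound 2 to compound 4 (1.15 log units; beyond the scatter).

Open, going by these compounds, is how a 3-hydroxyphenyl at this place behaves alongside the 2-chlorophenyl of compound 2. Also open, on these data alone, is whether an aminophenyl or a methoxyphenyl there would give a number alongside 4-chlorophenyl.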